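The compounds below may be only part of what the source reports. "The series", "measured", "known", "first", "only" and "open" are said of these compounds alone.

Compound 1 `COc1ccc2ncc(-c3nn[nH]n3)cc2c1`: 10 mg/kg
Compound 2 `O=C(O)c1cnc2ccc(C3CCCCC3)cc2c1`: > 25 mg/kg

Two compounds on the shared core have been run in a functional assay on the whole organism (strain Sprague-Dawley) for inhibition, with Rattus norvegicus as the target; a higher number here means that more compound is needed for the effect, a lower number that less compound is needed. Compound 1 gives a numbered minimum effective dose of 10 mg/kg. For compound 2 the read-out is a limit of the assay and not a number, > 25 mg/kg, as noted in the limit of > 25 mg/kg in this assay, at which 1 of the 2 values shown sits; compound 2 therefore stands at the limit, with no figure of its own to compare. Compound 3 `COc1ccc2ncc(C(=O)O)cc2c1` has not been measured in this assay. It differs from compound 2 in one place: methoxy in place of cyclohexyl on an aromatic carbon. Among the compounds with values here, no measured pair differs in only one place, so the size of this step cannot be read from a measured step; compound 3 does carry the same methoxy as compound 1. The step of an at least 2.0-fold lower number from compound 2 to compound 3 (0.31 log units; beyond the scatter) is expected to run toward less compound being needed, beyond the usual scatter. Compound 3 is expected to show a minimum effective dose near 12 mg/kg, in the range 4 mg/kg to 35 mg/kg.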

Compound 3, minimum effective dose: > 5 mg/kg
Compound 3: a limit, no number; the forecaster's own chance of this, stated with the estimate: 35%; the middle value is on the limit's open side.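

Compound 3 returns only a limit of the assay, > 5 mg/kg, so neither the step from compound 2 to compound 3 nor the step from compound 1 to compound 3 can be read. On these data alone, it remains open whether methoxy in place of cyclohexyl, or carboxy in place of 2H-tetrazol-5-yl, shifts the minimum effective dose.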